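Swapping 4-methoxynaphthalen-1-yl for thiophen-2-yl on the shared core

A few compounds are considered here, and "the series" means these few. Any claim that something is new, unique, unknown or untested is made for them only; others in the source may bear on it.

Of the compounds shown here, three sharing one core have been tested in a functional assay on Ehrlich cells (Mus musculus) for antiproliferative activity, read by trypan blue exclusion, with a stated time of 2 h; a lower number here means a stronger inhibitor, a higher number a weaker inhibitor. Compound 1 (`N#CC1=C(N)N(c2ccc(S(N)(=O)=O)cc2)C2=C(C(=O)CCC2)C1/C=C/c1ccccc1`) gives > 100 ug/mL, which is a limit of the assay. Compound 2 (`N#CC1=C(N)N(c2ccc(S(N)(=O)=O)cc2)C2=C(C(=O)CCC2)C1c1ccc(Cl)cc1Cl`) gives 25 ug/mL. Compound 3 (`COc1ccc(C2C(C#N)=C(N)N(c3ccc(S(N)(=O)=O)cc3)C3=C2C(=O)CCC3)c2ccccc12`) gives 70 ug/mL, the higher of the two values that are actual numbers.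

Compound 4 (`N#CC1=C(N)N(c2ccc(S(N)(=O)=O)cc2)C2=C(C(=O)CCC2)C1c1cccs1`) carries thiophen-2-yl in place of 4-methoxynaphthalen-1-yl on a saturated ring carbon. Among the compounds with values here, no measured compound carries thiophen-2-yl, so the evidence is indirect. The closest guide is a 2.8-fold higher number from compound 2 to compound 3 (0.45 log units; beyond the scatter), which shows that replacing one aromatic group with another at this carbon can shift the number. The other step at this carbon with a clear size is an at least 4.0-fold lower number from compound 1 to compound 2 (0.60 log units; beyond the scatter), though it rests on a limit. The remaining step, an at least 1.4-fold lower number from compound 1 to compound 3 (0.15 log units; that floor lies within the scatter), adds little.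

In this assay, the expected change is a 1.6-fold lower number from compound 3 to compound 4 (0.19 log units; within the scatter), a small move towards a lower number. Compound 4 is estimated at 45 ug/mL, with an expected range from 18 ug/mL to 110 ug/mL.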

Compound 4, half-maximal inhibitory concentration: 5 ug/mL
The estimate for compound 4 lay 9.0-fold (0.95 log units) above the measured number; the measured number lies below the stated range.
By their numbers in this assay, from the lowest: compound 4; then compound 2; then compound 3. At a limit, above all of these: compound 1.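

At this saturated ring carbon, a small five-membered aromatic ring outperforms both larger aromatic groups in this assay: thiophen-2-yl gives a 14-fold lower number from compound 3 to compound 4 (1.15 log units; beyond the scatter) and a 5.0-fold lower number from compound 2 to compound 4 (0.70 log units; beyond the scatter). Within the data shown here, compound 4 is therefore the strongest inhibitor of the four, and the group at this carbon can move the number much further than the earlier compounds showed. The step from the 2-phenylethenyl compound, an at least 20-fold lower number from compound 1 to compound 4 (1.30 log units; beyond the scatter), has only a floor for its size, as compound 1 stands at a limit of the assay: the limit of > 100 ug/mL in this assay, at which 1 of the 4 values shown sits.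

The compounds shown do not separate the effect of the sulfur-containing five-membered ring from that of the lower heavy-atom count of thiophen-2-yl. Unsubstituted phenyl, furan-2-yl and thiophen-3-yl at this carbon would bear on that question, and a thiophen-2-yl ring carrying a chlorine atom or a methyl group remains open as well.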